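This account rests on a few compounds, and the source may have more. Where it says the series, first, only, none or still open, it means among the compounds named here.

Measured so far, as inhibition in an assay on CHO cells for displacement of a labelled ligand from adenosine receptor A1 (Homo sapiens), read by scintillation counting, tested at 10 uM; on this read-out higher numbers stand for more inhibition at the one concentration tested (going by the name of the read-out) and lower numbers for less inhibition:

compound 1, `CC(C)(C)Cc1c(Br)sc(N)c1C(=O)c1cccc(Cl)c1`: 1%
compound 2, `CC(C)(C)Cc1c(-c2ccccc2)sc(N)c1C(=O)c1ccc(Cl)cc1`: 1%

Compound 2 stands level with compound 1 at the digits shown; the two values lie within the scatter of each other, so no order between them can be read. Neither compound shows measurable displacement at the concentration used.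

Compound 3, `CC(C)(C)Cc1c(-c2ccccc2)sc(N)c1C(=O)c1cccc(Cl)c1`, is not yet measured. It differs from compound 2 in one place: 3-chlorophenyl in place of 4-chlorophenyl on a carbonyl carbon. Compound 1 already carries a 3-chlorophenyl on its carbonyl carbon and gives 1% in this assay, so the entering group on its own has not produced inhibition in a related compound. With both measured compounds at the floor of the read-out, no step beyond the scatter is expected in either direction.

Compound 3 is therefore expected to give 2%, within -8% to 12%. The estimated step of a number 1 percentage points higher from compound 2 to compound 3 (within the scatter) is expected to lie within the scatter.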

Compound 3, a percentage reported as inhibition, at one concentration (the size of the read-out at that concentration, not a potency): 2%
Beside the measured number, compound 3's estimate shows no gap at the digits printed; the measured number falls inside the stated range.
By their numbers in this assay, from the lowest: compounds 1, 2 and 3 (each within the scatter of the next).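

In this assay, 3-chlorophenyl in place of 4-chlorophenyl on a carbonyl carbon gives a number 1 percentage points higher from compound 2 to compound 3 (within the scatter), so this swap of the two chlorophenyl groups does not separate the pair on this read-out. Phenyl in place of bromo on an aromatic carbon, with 3-chlorophenyl held on the carbonyl carbon, gives a number 1 percentage points higher from compound 1 to compound 3 (within the scatter), the first single-place comparison at that aromatic carbon, and it does not separate the pair either. No supporting measurement bears on these results.

From the compounds shown here alone, all three compounds sit at the floor of the read-out, so it remains open whether either place can influence displacement at all. Going by these compounds, what an amine or a carboxylic acid on that aromatic carbon, or a pyridine ring on the carbonyl carbon, would give also remains open.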